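Nitro and methyl substituents on a triaryl pyrazolopyrimidinone core

The source may hold more compounds than are shown below. What is called first, only, known or untested is meant among the compounds shown, and "the series" means these compounds.

Compound 1 `O=c1c2c(Nc3ccccc3)nn(-c3ccccc3)c2nc(Nc2ccccc2)n1-c1ccccc1`: 43.4%
Compound 2 `O=c1c2c(Nc3ccc([N+](=O)[O-])cc3)nn(-c3ccccc3)c2nc(Nc2ccccc2)n1-c1ccccc1`: 29%
Compound 3 `Cc1ccc(Nc2nn(-c3ccccc3)c3nc(Nc4ccccc4)n(-c4ccccc4)c(=O)c23)cc1`: 53.4%

In a functional assay on the whole organism (strain Wistar albino) for inhibition, with Rattus norvegicus as the target, read by paw edema, with a stated time of 2 h, at a dose of 25 mg/kg by the oral route (on this read-out higher numbers stand for more inhibition at the one dose given (going by the name of the read-out) and lower numbers for less inhibition), compound 1 gives 43.4%. Compound 2 differs by nitro in place of hydrogen on an aromatic carbon and gives a number 14.4 percentage points lower from compound 1 to compound 2 (beyond the scatter). Compound 3 differs from compound 1 by methyl in place of hydrogen on an aromatic carbon; in this assay compound 3 gives 53.4%, which lies within the scatter of the value of compound 1.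

Compound 4 `Cc1ccc(Nc2nn(-c3ccc([N+](=O)[O-])cc3)c3nc(Nc4ccccc4)n(-c4ccccc4)c(=O)c23)cc1` has not been measured. It differs from compound 3 by nitro in place of hydrogen on an aromatic carbon. The same change, by the computed difference, was made from compound 1 to compound 2, though cut one bond further out the earlier change also read anilino to (4-nitrophenyl)amino, which the present one does not. Resting on a number 14.4 percentage points lower from compound 1 to compound 2 (beyond the scatter), the step from compound 3 to compound 4 in this assay is expected to be a number 13.4 percentage points lower from compound 3 to compound 4 (beyond the scatter). Compound 4 is therefore estimated at 40%, between 26% and 54%.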

Compound 4, a percentage reported as inhibition, in the whole organism at one dose (the size of the read-out at that dose, not a potency): 39.8%
Estimate against measurement, compound 4: 0.2 percentage points above; measured number inside the range.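

Nitro in place of hydrogen gives a number 13.6 percentage points lower from compound 3 to compound 4 (beyond the scatter) in this assay and so moves the number the same way as on the core of compound 1. The size of the step carries from one core to the other with no difference that can be told apart: the same change on two cores in this assay, a number 14.4 percentage points lower (beyond the scatter) from compound 1 to compound 2 and a number 13.6 percentage points lower (beyond the scatter) from compound 3 to compound 4, 0.8 percentage points apart, within the scatter of two such steps

This rests on a single pair of steps at one dose and time, and the two differ in where the nitro stands, anilino to (4-nitrophenyl)amino against phenyl to 4-nitrophenyl, so it shows neither that the step holds on further cores nor how much the site of the nitro matters.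

Going by these compounds, whether an amine or a carboxylic acid in the place of the nitro gives a step of like size stays open. So does whether methyl and nitro together follow the same course on the other aromatic rings of the shared core.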